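This account rests on a few compounds, and the source may have more. Where it says the series, first, only, none or still open, it means among the compounds named here.

In a functional assay on SMMC-7721 cells (Homo sapiens) for cytotoxicity, read by MTT assay, with a stated time of 24 h (a lower number here means a stronger inhibitor, a higher number a weaker inhibitor), compound 1 (`O=C1/C(=C/c2ccccc2F)CN(S(=O)(=O)c2ccc(F)cc2)C/C1=C\c1ccccc1F`) gives 8370 nM and sits level with the other two measured compounds. Compound 2 (`CC(=O)Nc1ccc(S(=O)(=O)N2C/C(=C\c3ccccc3F)C(=O)/C(=C/c3ccccc3F)C2)cc1`) reads 7490 nM and compound 3 (`CC(=O)Nc1ccc(S(=O)(=O)N2C/C(=C\c3cccc([N+](=O)[O-])c3)C(=O)/C(=C/c3cccc([N+](=O)[O-])c3)C2)cc1`) reads 8420 nM here, so compound 1 lies within the scatter of both. For the measured compounds named here, the only single-place step measured is a 1.1-fold lower number from compound 1 to compound 2 (0.05 log units; within the scatter) and it lies at a different place from the change now in view.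

Compound 4 (`N#Cc1ccc(/C=C2\CN(S(=O)(=O)c3ccc(F)cc3)C/C(=C\c3ccccc3F)C2=O)cc1`) is still unmeasured. Its change from compound 1 is 4-cyanophenyl in place of 2-fluorophenyl on a double-bonded chain carbon bound to a double-bonded ring carbon on a double-bonded chain carbon bound to a double-bonded ring carbon. Going by the values given here, no measured step isolates that place. Against compound 2, the aryl groups on such carbons differ in compound 3, which reads 8420 nM and so offers the only indirect hint.

In this assay no shift beyond the scatter is therefore expected, and the estimated step is a 1.2-fold lower number from compound 1 to compound 4 (0.08 log units; within the scatter) in size. For compound 4 the expected value is 7000 nM with an estimated range of 3000 nM to 14000 nM for now.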

Compound 4, half-maximal inhibitory concentration: 10300 nM
For compound 4 the middle estimate is 1.5-fold (0.17 log units) below the measured one; the measured number falls inside the stated range.
By their numbers in this assay, from the lowest: compounds 2, 1, 3 and 4 (each within the scatter of the next).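

For the compounds shown here, replacing 2-fluorophenyl with 4-cyanophenyl on a double-bonded chain carbon bound to a double-bonded ring carbon gives, in this assay, a 1.2-fold higher number from compound 1 to compound 4 (0.09 log units; within the scatter) and provides the first direct reading at this place. This exchange therefore leaves the number within the scatter, as does the change at a different place, a 1.1-fold lower number from compound 1 to compound 2 (0.05 log units; within the scatter), so neither single-place step yet separates any compound from compound 1. No available evidence bears on this result.

One exchange cannot show whether the place is generally tolerant, since only 4-cyanophenyl has been compared directly with 2-fluorophenyl here. On these data alone, whether a phenyl ring carrying a carboxylic acid or a primary amine at this place would move the number beyond the scatter remains open.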